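The source may report more compounds than this note shows. Statements on the series, on what has been measured and on what is new or still open speak of the compounds shown alone.

Measured compounds in a functional assay for activation of Alpha-1B adrenergic receptor (Homo sapiens), read by calcium flux; on this read-out higher numbers stand for an effect only at larger amounts of compound and lower numbers for an effect already at smaller amounts:
- compound 1, `c1csc(-c2ccccc2NCC2=NCCN2)c1`: 5.75 nM
- compound 2, `Cc1ccc(-c2ccccc2NCC2=NCCN2)o1`: 46.8 nM
- compound 3, `FC(F)(F)c1cccnc1-c1ccccc1NCC1=NCCN1`: only a limit, < 100000 nM

Compound 2 holds the highest of the two numbers available in this assay; its nearest neighbour is compound 1, and the step of an 8.1-fold higher number from compound 1 to compound 2 (0.91 log units; beyond the scatter) shows that exchanging one five-membered aromatic ring for another already moved the number beyond the scatter. For compound 3 the assay gave only a limit, < 100000 nM, rather than a number.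

Compound 4, `CO/N=C/c1ccccc1NCC1=NCCN1`, differs from compound 2 in that (a group of 4 heavy atoms (2 carbon, 1 nitrogen, 1 oxygen; no ring) in place of a group of 6 heavy atoms (5 carbon, 1 oxygen; one five-membered aromatic ring with 1 hetero atom), on an aromatic carbon). For the measured compounds named here, no measured step matches this change: the one step that exists swapped one ring for another, whereas here the ring is removed altogether and an open, non-ring group enters on an aromatic carbon. Since the milder ring swap from compound 1 to compound 2 cost an 8.1-fold higher number from compound 1 to compound 2 (0.91 log units; beyond the scatter), a larger loss is expected here. Compound 4 is therefore estimated at 600 nM (range 80 nM to 6000 nM), a step of a 13-fold higher number from compound 2 to compound 4 (1.11 log units; beyond the scatter) expected to be weakening.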

Compound 4, half-maximal effective concentration: < 5020 nM
Compound 4: only a limit was reported; the forecaster's own chance of this, stated with the estimate: 15%; the middle value is on the limit's open side.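

In this assay compound 4 gave only a limit, < 5020 nM. Its steps from compound 1 and from compound 2 therefore cannot be read. The compounds shown leave open how the number for compound 4 truly compares with those of compound 1 and compound 2.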